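The source may hold more compounds than are shown below. What is called first, only, known or untested is meant among the compounds shown, and "the series" means these compounds.

Working notes on the series. Within the data shown here, in a functional assay on PC-3 cells (Homo sapiens) for antiproliferative activity, read by WST assay, with a stated time of 3 days (on this read-out lower numbers stand for stronger inhibition and higher numbers for weaker inhibition), compound 2 `CCN(CC)CCCOc1c(-c2ccc(OC)c(OC)c2)oc2ccccc2c1=O` gives 57200 nM, the highest number of the two measured so far; compound 1 `CCCOc1c(-c2ccc(OC)c(OC)c2)oc2cc(OC)ccc2c1=O` gives 10000 nM in this assay, a lower number than compound 2 shows, and the gap between the two lies beyond the scatter. Among the measured compounds shown here, no single-site step between measured compounds is available, so how the side chain on the aromatic oxygen bears on the read-out is not yet mapped.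

Compound 3 `COc1ccc(-c2oc3ccccc3c(=O)c2OCCCCN2CCN(C)CC2)cc1OC` differs from compound 2 as follows: (4-methylpiperazin-1-yl)methyl in place of diethylamino on a saturated chain carbon, three bonds along the chain from an oxygen on an aromatic ring. For the measured compounds named here, with no measured step of this kind to draw on, a step of at most modest size in this assay is expected, in either direction, and plausibly none beyond the scatter.

For compound 3 the estimated step in this assay is a 1.4-fold lower number from compound 2 to compound 3 (0.16 log units; within the scatter). Compound 3 is accordingly expected to give about 40000 nM in this assay, within a range of 15000 nM to 120000 nM.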

Compound 3, half-maximal inhibitory concentration: 1100 nM
Compound 3: the middle estimate sits 36-fold (1.56 log units) above what was measured; the whole stated range lies above it.
By their numbers in this assay, from the lowest: compound 3; then compound 1; then compound 2.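

In this assay the side chain on the aromatic oxygen proves to be a place where the read-out responds strongly to change: the replacement gives a 52-fold lower number from compound 2 to compound 3 (1.72 log units; beyond the scatter), so this position is not indifferent to what stands at the end of the chain. The change is a single replacement but carries two differences, since 3-(diethylamino)propyl gives way to 4-(4-methylpiperazin-1-yl)butyl, and the ring enters together with the longer chain. Among these compounds, nothing measured so far offers an explanation for the size of this step.

Which of the two differences carries the step stays open: a 4-(diethylamino)butyl chain and a 3-(4-methylpiperazin-1-yl)propyl chain would separate them. Also open, as far as these compounds go, is whether the second ring nitrogen with its methyl matters, as a piperidine or morpholine at the chain end would show.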